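This account rests on a few compounds, and the source may have more. Where it says the series, first, only, none or still open, it means among the compounds named here.

Working notes on the series. Compound 1 `CN(C)c1cccc(C(=O)N[C@H]2CCC[C@H](NC(=O)c3cccc(Cl)c3)C2)c1` is assessed in a functional assay on HEK293 cells for antagonist activity at metabotropic glutamate receptor 5 (Homo sapiens), read by FLIPR and calcium flux; on this read-out higher numbers stand for weaker inhibition and lower numbers for stronger inhibition. In this assay compound 1 gives > 10000 nM, which is a limit of the assay and not a number, as noted in the limit of > 10000 nM in this assay, at which 1 of the 2 values shown sits. Compound 2 `O=C(N[C@H]1CCC[C@H](NC(=O)c2cccc(F)c2)C1)c1cccc(F)c1` gives 593 nM in this assay. Compound 3 `O=C(N[C@H]1CCC[C@H](NC(=O)c2cccc(Cl)c2)C1)c1ccc(F)cc1` has not been measured; it differs from compound 1 by 4-fluorophenyl in place of 3-(dimethylamino)phenyl on a carbonyl carbon. Among the measured compounds shown here, no measured step between neighbours is available, so the expectation rests on compound 2 at 593 nM. The step from compound 1 to compound 3 is expected to be an at least 5.0-fold lower number from compound 1 to compound 3 (0.69 log units; beyond the scatter), towards stronger inhibition. Compound 3 is estimated at 2000 nM, within 400 nM to 10000 nM.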

Compound 3, half-maximal inhibitory concentration: 194 nM
For compound 3 the middle estimate is 10-fold (1.01 log units) above the measured one; the measured number lies below the stated range.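

Working at the position on a carbonyl carbon, 4-fluorophenyl in place of 3-(dimethylamino)phenyl gives an at least 51-fold lower number from compound 1 to compound 3 (1.71 log units; beyond the scatter) in this assay, so this position can carry a large change. The size of the step has only a lower bound, since compound 1 stands at a limit and not a number: the limit of > 10000 nM in this assay, at which 1 of the 3 values shown sits.

The compounds shown do not separate the removal of dimethylamino from the arrival of fluorine, as both change in one step. Going by these compounds, how a methoxy group or a carboxylic acid on that phenyl ring would read remains open.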